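A few compounds are considered here, and "the series" means these few. Any claim that something is new, unique, unknown or untested is made for them only; others in the source may bear on it.

Working notes on the series. In a functional assay on NCI-H460 cells (Homo sapiens) for cytotoxicity, read by MTT assay, with a stated time of 72 h (a lower number here means a stronger inhibitor, a higher number a weaker inhibitor), compound 1 `CN(C)CCNc1nc(-c2ccc(NC(=O)Nc3ccc(Cl)cc3)cc2)nc2c(Cl)c(Cl)sc12` gives 300 nM. For the measured compounds named here, compound 2 `CN(C)CCNc1nc(-c2ccc(NC(=O)Nc3ccccc3Cl)cc2)nc2c(Cl)c(Cl)sc12` gives 440 nM in this assay, the higher of the two numbers measured so far; its nearest neighbour is compound 1, and the single step on record, a 1.5-fold higher number from compound 1 to compound 2 (0.17 log units; within the scatter), lies within the scatter, so the two compounds are not separable on these numbers.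

Compound 3 `CCN(CC)CCCNc1nc(-c2ccc(NC(=O)Nc3ccccc3Cl)cc2)nc2c(Cl)c(Cl)sc12` differs from compound 2 by (diethylamino)methyl in place of dimethylamino on a saturated chain carbon, two bonds along the chain from a nitrogen on an aromatic ring. Going by the values given here, no measured step touches this part of the molecule: the only step available, between compound 1 and compound 2, changes the chlorophenyl on the urea nitrogen and is itself within the scatter, so it gives no direction for the present change. With nothing in the data pointing either way, the expectation for this assay is no step beyond the scatter, that is no change at the digits printed from compound 2 to compound 3 (within the scatter). Compound 3 is therefore estimated at 440 nM, with a range of 150 nM to 1300 nM.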

Compound 3, half-maximal inhibitory concentration: 330 nM
For compound 3 the middle estimate is 1.3-fold (0.12 log units) above the measured one, within the range that was stated.
By their numbers in this assay, from the lowest: compounds 1, 3 and 2 (each within the scatter of the next).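

In this assay, for the compounds shown here, the step at this position, a 1.3-fold lower number from compound 2 to compound 3 (0.12 log units; within the scatter), is the first on record to touch the amine side chain rather than the chlorophenyl on the urea nitrogen. It shows that (3-(diethylamino)propyl)amino can stand in place of (2-(dimethylamino)ethyl)amino without separating compound 3 from compound 2 on these numbers, so this position tolerates the larger group here. No measured evidence bears on the reason for this result.

Chain length and the substituents on the amine change together in this step, so a 3-(dimethylamino)propyl or 2-(diethylamino)ethyl chain would be needed to read either change alone. From the compounds shown here alone, whether the side chain needs a basic amine at all also stays open, and a hydroxyl or morpholine at the chain end would address this.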